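Methoxy on the Second Ring: Expected Cytotoxicity of Compound 4

A few compounds are considered here, and "the series" means these few. Any claim that something is new, unique, unknown or untested is made for them only; others in the source may bear on it.

Compound 1 `O[C@@H]1Cc2ccccc2N[C@H](c2ccccc2)C1` is the parent of this small set. In an ADME assay on THP-1 cells (Homo sapiens) for cytotoxicity, read by MTT assay, with a stated time of 72 h (on this read-out lower numbers stand for higher toxicity in this test and higher numbers for lower toxicity in this test), compound 1 gives > 300000 nM, which is a limit of the assay rather than a measured number. Two relatives carry a halogen on an aromatic carbon of the shared core. Compound 2 `O[C@@H]1Cc2cc(Br)ccc2N[C@H](c2ccccc2)C1` gives 185000 nM in this assay. Compound 3 `O[C@@H]1Cc2cc(F)ccc2N[C@H](c2ccccc2)C1` gives > 300000 nM in this assay, again a limit. Adding bromo gives an at least 1.6-fold lower number from compound 1 to compound 2 (0.20 log units; that floor lies within the scatter), adding fluoro gives a step that the two limits leave unreadable from compound 1 to compound 3, and the swap gives an at least 1.6-fold higher number from compound 2 to compound 3 (0.20 log units; that floor lies within the scatter); with the limit of > 300000 nM in this assay, at which 2 of the 3 values shown sit, little can be read from any of them. Compound 4 `COc1cccc([C@@H]2C[C@H](O)Cc3ccccc3N2)c1` differs from compound 1 by methoxy in place of hydrogen on an aromatic carbon. Among the compounds with values here, no measured step touches that ring, so the three steps bear on compound 4 only as a sign that a small substituent barely moves this read-out. Compound 4 is therefore expected to sit at or near the limit, an estimated step of a number no higher from compound 1 to compound 4 (the limit leaves the size open). The estimate for compound 4 is 300000 nM, between 150000 nM and 600000 nM.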

Compound 4, half-maximal cytotoxic concentration: > 300000 nM
Compound 4 was reported as a limit; the forecaster's own chance of this, stated with the estimate: 70%; the middle value sits exactly at the limit.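

Compound 1 and compound 4 are both reported only as limits in this assay, so no step between them can be read: the limit of > 300000 nM in this assay, at which 3 of the 4 values shown sit.

The compounds shown leave open whether methoxy in place of hydrogen changes this read-out at all, and in which direction.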